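Removing the triple bond from compound 3

The source may hold more compounds than are shown below. What is called first, only, known or untested is meant among the compounds shown, and "the series" means these compounds.

compound 1 `CCCC#Cc1cc([C@@H]2O[C@H](CO)[C@@H](O)[C@H]2O)n2ncnc(N)c12`: 40 nM
compound 2 `CCCCC#Cc1cc([C@@H]2O[C@H](CO)[C@@H](O)[C@H]2O)n2ncnc(N)c12`: 1000 nM
compound 3 `Nc1ncnn2c([C@@H]3O[C@H](CO)[C@@H](O)[C@H]3O)cc(C#Cc3ccc(F)cc3)c12`: > 100000 nM (a limit)

In a functional assay on LN-229 cells (Homo sapiens) for antiproliferative activity, with a stated time of 72 h (on this read-out lower numbers stand for stronger inhibition and higher numbers for weaker inhibition), compound 3 gives > 100000 nM, which is a limit and not a number. Its true position on the scale is therefore unknown.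

The next compound is compound 4 `Nc1ncnn2c([C@@H]3O[C@H](CO)[C@@H](O)[C@H]3O)cc(-c3ccc(F)cc3)c12`, with this change: 4-fluorophenyl in place of 2-(4-fluorophenyl)ethynyl on an aromatic carbon. In words, 4-fluorophenyl stands in place of 2-(4-fluorophenyl)ethynyl on an aromatic carbon.

The closest measured evidence is an at least 2500-fold higher number from compound 1 to compound 3 (3.39 log units; beyond the scatter) and an at least 100-fold higher number from compound 2 to compound 3 (2.00 log units; beyond the scatter). Both are large and both involve 4-fluorophenyl on a triple-bonded carbon. The chain change alone also gives a large move, a 25-fold higher number from compound 1 to compound 2 (1.40 log units; beyond the scatter). None of these steps removes the triple bond, so they bear on compound 4 only indirectly.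

A moderate to large move toward a lower number is expected, though compound 4 may also stay at the limit. The estimated change is an at least 5.0-fold lower number from compound 3 to compound 4 (0.69 log units; beyond the scatter). For compound 4 the expected value is 20000 nM, with an estimated range of 1000 nM to 100000 nM.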

Compound 4, half-maximal inhibitory concentration: 65600 nM
Compound 4: the middle estimate sits 3.3-fold (0.52 log units) below what was measured; the range from low to high includes it.
By their numbers in this assay, from the lowest: compound 1; then compound 2; then compound 4. At a limit, above all of these: compound 3.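

In this assay, 4-fluorophenyl set directly on the aromatic carbon, with no triple bond, still leaves compound 4 well behind both compounds with alkyl-substituted triple bonds: a 66-fold higher number from compound 2 to compound 4 (1.82 log units; beyond the scatter) and a 1600-fold higher number from compound 1 to compound 4 (3.21 log units; beyond the scatter). Taking the triple bond out of the 2-(4-fluorophenyl)ethynyl group gives an at least 1.5-fold lower number from compound 3 to compound 4 (0.18 log units; that floor lies within the scatter), and that floor does not establish a real change at this position. Compound 3 gives > 100000 nM, which is a limit and not a number: the limit of > 100000 nM in this assay, at which 1 of the 4 values shown sits.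

Open, from the compounds shown here alone, is how a saturated chain such as hexyl, or a phenyl without the fluorine, would read on this aromatic carbon. Compound 1 and compound 2 both carry a triple bond, so the share of that bond in their values cannot be read from the compounds shown.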